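A Larger Group on the Aromatic Nitrogen

The compounds below may be only part of what the source reports. "The series", "measured", "known", "first", "only" and "open" are said of these compounds alone.

In a functional assay on HT-29 cells (Homo sapiens) for inhibition, read by luminescence and CellTiter-Glo, with a stated time of 24 h (a lower number here means that less compound is needed, a higher number that more compound is needed for the effect), compound 1 (`CN1C(=S)[C@@H](NC(=O)c2nc(Cc3ccccc3)n(C3CCCC3)n2)COc2ccccc21`) gives 3530 nM, and compound 2 (`CN1C(=S)[C@@H](NC(=O)c2nc(Cc3ccccc3)n(CC3CCOCC3)n2)COc2ccccc21`) gives 6310 nM. Among the compounds with values here, these are the only two numbers available, and they lie within the scatter of each other, so compound 2 stands level with compound 1. Compound 3 (`CN1C(=S)[C@@H](NC(=O)c2nc(Cc3ccccc3)n(C3CCN(C(=O)OC(C)(C)C)C3)n2)COc2ccccc21`) keeps the shared core and differs from compound 2 on an aromatic nitrogen: a group of 12 heavy atoms (9 carbon, 1 nitrogen, 2 oxygen; one five-membered non-aromatic ring with 1 hetero atom) in place of a group of 7 heavy atoms (6 carbon, 1 oxygen; one six-membered non-aromatic ring with 1 hetero atom), on an aromatic nitrogen. Within the data shown here, one measured step bears on this change, made at the same place: a 1.8-fold higher number from compound 1 to compound 2 (0.25 log units; within the scatter). Among the measured compounds shown here, it is a single step, and no group as large as the one in compound 3 has been measured there, so it offers only limited guidance. No step beyond the scatter is therefore expected in this assay. The expected step is a 1.4-fold lower number from compound 2 to compound 3 (0.15 log units; within the scatter). For compound 3 the estimated value is 4500 nM, with an expected range from 1300 nM to 14000 nM.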

Compound 3, half-maximal effective concentration: > 10000 nM
Compound 3: no number, only a limit (the forecaster's own chance of this, stated with the estimate: 10%); at least 2.2-fold (0.34 log units) between middle value and limit.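

In this assay compound 3 gives no number, only a limit: the limit of > 10000 nM in this assay, at which 1 of the 3 values shown sits.

Even so, the position proves not to be indifferent to what it carries, as the change from cyclopentyl to the group of 12 heavy atoms gives an at least 2.8-fold higher number from compound 1 to compound 3 (0.45 log units; beyond the scatter), the only step at this aromatic nitrogen that lies beyond the scatter. Measured against (oxan-4-yl)methyl, the same group gives an at least 1.5-fold higher number from compound 2 to compound 3 (0.19 log units; that floor lies within the scatter), so this comparison alone does not separate the two groups.

The compounds shown leave open how far the true value of compound 3 lies past its limit, and whether the higher number goes with the count of heavy atoms or with the particular group that enters. Nor do they show how a five-membered ring bearing a free amine, or a longer carbon chain, on this nitrogen would read in this assay.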